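Iminosugar carboxylic acids as beta-glucuronidase inhibitors

A few compounds are considered here, and "the series" means these few. Any claim that something is new, unique, unknown or untested is made for them only; others in the source may bear on it.

Compound 1 `O=C(O)[C@H]1CNC[C@@H](O)[C@@H]1O` is the reference point. Going by the values given here, in an assay on isolated protein for inhibition of beta-glucuronidase (Bos taurus), with a stated time of 30 min, at pH 4.5 (on this read-out higher numbers stand for weaker inhibition and lower numbers for stronger inhibition), compound 1 gives 48 nM, the lowest of the three numbers so far. Compound 2 `O=C(O)[C@H]1NC(=O)[C@H](O)[C@@H](O)[C@@H]1O` gives 132 nM in this assay, a difference from compound 1 that lies beyond the scatter. Compound 3 `O=C(O)[C@H]1OC(=O)[C@H](O)[C@@H](O)[C@@H]1O` gives 4870 nM, the highest number, far beyond the scatter from compound 1. Among the compounds with values here, no single-point step between measured compounds is available, so the effect of an alkyl group on the core is unknown here.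

Compound 4 `CCC[C@@H]1NC[C@@H](O)[C@H](O)[C@H]1C(=O)O` carries propyl in place of hydrogen on a saturated ring carbon. For compound 4 the expected step is a 2.5-fold higher number from compound 1 to compound 4 (0.40 log units; beyond the scatter), a modest weakening at most, possibly none beyond the scatter. Compound 4 is estimated at 120 nM, with a range from 20 nM to 700 nM.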

Compound 4, inhibition constant: 32200 nM
The estimate for compound 4 lay 270-fold (2.43 log units) below the measured number; the measured number lies above the stated range.
By their numbers in this assay, from the lowest: compound 1; then compound 2; then compound 3; then compound 4.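

In this assay, propyl in place of hydrogen on this saturated ring carbon, next to the ring nitrogen and next to the ring atom that bears a carboxy group, gives a 670-fold higher number from compound 1 to compound 4 (2.83 log units; beyond the scatter), a large loss of inhibition. Going by these compounds alone, this position on the core of compound 1 therefore tolerates the propyl group poorly, which the earlier compounds could not show. Nothing available explains the loss.

Open, going by these compounds, is whether a methyl group here retains more of the inhibition than propyl. Also open, on these data alone, is whether a hydroxymethyl group or an amine on a chain at this carbon behaves like propyl.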